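Fluoro for Methyl on the Aryl Ring of a Pyrazolopiperidine Urea

The compounds below may be only part of what the source reports. "The series", "measured", "known", "first", "only" and "open" are said of these compounds alone.

Measured compounds:
compound 1, `CCN1CCc2c(c(C)nn2C(=O)Nc2c(C)cccc2C)C1`, 12.2%
compound 2, `CCN1CCc2c(c(C)nn2C(=O)Nc2cc(C)ccc2C)C1`, 2.6%
compound 3, `CCN1CCc2c(c(C(C)(C)C)nn2C(=O)Nc2cc(C)ccc2C)C1`, 0%

In a functional assay on the whole organism (strain Swiss albino) for inhibition, with Mus musculus as the target, in the formalin test, with stated times of 30 min and 5 min, at a dose of 100 mg/kg (a higher number here means more inhibition at the dose given (going by the name of the read-out), a lower number less inhibition), compound 3 gives 0%, the lowest of the three numbers. Its nearest neighbour is compound 2, which gives 2.6%, and the two lie within the scatter of each other. Compound 1 gives 12.2%, and its gap to compound 3 lies beyond the scatter.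

Compound 4, `CCN1CCc2c(c(C(C)(C)C)nn2C(=O)Nc2cc(C)ccc2F)C1`, is not yet measured. It differs from compound 3 by fluoro in place of methyl on an aromatic carbon; cut one bond further out, the change reads 2,5-dimethylphenyl to 2-fluoro-5-methylphenyl. Going by the values given here, the only step measured within one change is a number 2.6 percentage points lower from compound 2 to compound 3 (within the scatter), which exchanges groups on the five-membered part of the core rather than on the aryl ring, so no measured step bears directly on the new change. All three numbers are small, and nothing suggests a large movement, so the expected step is a number 5 percentage points higher from compound 3 to compound 4 (within the scatter), none beyond the scatter. Compound 4 is therefore estimated at 5%, with a range from 0% to 20%.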

Compound 4, a percentage reported as inhibition, in the whole organism at one dose (the size of the read-out at that dose, not a potency): 7%
Compound 4: the middle estimate sits 2 percentage points below what was measured; low and high end bracket the measured number.
By their numbers in this assay, from the lowest: compounds 3, 2, 4 and 1 (each within the scatter of the next, the first and the last beyond it).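

Going by these compounds alone, the step of a number 7 percentage points higher from compound 3 to compound 4 (within the scatter) in this assay is the first measured on the aryl ring itself, at the carbon ortho to a large group and para to a methyl group. Starting from compound 3 at 0%, it shows that fluoro in place of methyl at this carbon does not, on its own, move the read-out beyond the scatter, so the change from 2,5-dimethylphenyl to 2-fluoro-5-methylphenyl has no effect that these numbers can separate from noise. No measurement at hand explains the result.

The compounds shown leave open whether a chloro, a methoxy or an amine on this same carbon would move the number beyond the scatter. They also leave open whether fluoro here would behave the same with methyl instead of tert-butyl on the core.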